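A few compounds are considered here, and "the series" means these few. Any claim that something is new, unique, unknown or untested is made for them only; others in the source may bear on it.

The series is built on a shared core; compound 1 is `O=C(NO)c1ccc(N(Cc2ccc(C3CCCCC3)cc2)C(=O)[C@H]2CCN2S(=O)(=O)c2c(F)c(F)c(F)c(F)c2F)cc1O`, compound 2 is `O=C(NO)c1ccc(N(Cc2ccc(C3CCOCC3)cc2)C(=O)[C@H]2CCN2S(=O)(=O)c2c(F)c(F)c(F)c(F)c2F)cc1O`, compound 3 is `O=C(NO)c1ccc(N(Cc2ccc(C3CCCCC3)cn2)C(=O)[C@H]2CCN2S(=O)(=O)c2c(F)c(F)c(F)c(F)c2F)cc1O` and the not yet measured compound 4 is `Cn1ccc2cc(N(Cc3ccc(C4CCCCC4)cn3)C(=O)[C@H]3CCN3S(=O)(=O)c3c(F)c(F)c(F)c(F)c3F)ccc2c1=O`. In an ADME assay on MCF-10A cells (Homo sapiens) for cytotoxicity, with a stated time of 72 h (a higher number here means that more compound is needed for the effect, a lower number that less compound is needed), compound 1 gives 7500 nM. For compound 2 the entry in this assay reads "not determined" (no result reported), so no result is reported. Compound 3 likewise stands with "not determined" (no result reported) in this assay, without a single number; it is one of two entries in the series for which no result is available, so compound 3 cannot be placed against compound 1 on the numbers shown. Between compound 3 and compound 4 the change is a group of 12 heavy atoms (10 carbon, 1 nitrogen, 1 oxygen; one six-membered aromatic ring of carbon only, one six-membered aromatic ring with 1 hetero atom) in place of a group of 11 heavy atoms (7 carbon, 1 nitrogen, 3 oxygen; one six-membered aromatic ring of carbon only), on an amide-type nitrogen. For the measured compounds named here, no step between two measured compounds is available for this change, so nothing in the measured data fixes its size or direction. The expectation rests on compound 1 alone, whose value of 7500 nM in this assay is the only measured point, and it is that the 3-hydroxy-4-(hydroxycarbamoyl)phenyl group leaving will move compound 4 toward a higher number, beyond the scatter. Compound 4 is estimated at 18000 nM in this assay, with a range from 5000 nM to 60000 nM.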

Compound 4, half-maximal effective concentration: 4400 nM
Compound 4: the middle estimate sits 4.1-fold (0.61 log units) above what was measured; the whole stated range lies above it.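

For the compounds shown here, compound 3 has no result in this assay, so compound 4 at 4400 nM gives no new step. The compounds shown leave open how replacing the 3-hydroxy-4-(hydroxycarbamoyl)phenyl group on the amide-type nitrogen acts in this assay, in size or direction. No measured evidence bears on this result.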